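Cytotoxicity limits in a stilbenoid series, methoxy step

The source may hold more compounds than are shown below. What is called first, only, known or untested is meant among the compounds shown, and "the series" means these compounds.

Measured so far:
- compound 1 `COc1ccc(/C=C/[C@@](C)(/C=C/c2ccc(O)cc2)CCC=C(C)C)cc1`: > 36600 nM
- compound 2 `CC(C)=CCC[C@@](C)(/C=C/c1ccccc1)/C=C/c1ccc(O)cc1`: > 36600 nM
- compound 3 `C=C[C@@](C)(/C=C/c1ccc(Nc2ccccc2)cc1)CCC=C(C)C`: > 36600 nM

All three values come from a functional assay on SEM cells (Homo sapiens) for cytotoxicity, with a stated time of 72 h; on this read-out lower numbers stand for an effect already at smaller amounts and higher numbers for an effect only at larger amounts of compound. For compound 1 the value > 36600 nM is a limit of the assay, not a number. For compound 2 the value > 36600 nM is likewise a limit. For compound 3 the value > 36600 nM is a limit as well; all three sit at the limit of > 36600 nM in this assay, at which 3 of the 3 values shown sit.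

The change from compound 2 to compound 1 is methoxy in place of hydrogen on an aromatic carbon, and the step it made, a step that the two limits leave unreadable from compound 2 to compound 1, cannot be read because both values are limits. The difference between the core of compound 2 and the core of compound 3 is not broken down here.

Compound 4 `C=C[C@@](C)(/C=C/c1ccc(Nc2ccc(OC)cc2)cc1)CCC=C(C)C` is not yet measured. It differs from compound 3 by methoxy in place of hydrogen on an aromatic carbon, the same change as from compound 2 to compound 1, at the same kind of place. Since that earlier step is unreadable and compound 3 itself only gives a limit, the step that the limit leaves unreadable from compound 3 to compound 4 is expected to be small, with compound 4 most likely again reported as a limit in this assay. The estimate for compound 4 in this assay is 50000 nM, between 20000 nM and 200000 nM.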

Compound 4, half-maximal effective concentration: > 36600 nM
Compound 4: only a limit was reported; the forecaster's own chance of this, stated with the estimate: 85%; the middle value lies beyond the limit too.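

In this assay the methoxy step from compound 3 to compound 4 cannot be read, because both compounds give only a limit of the assay: the limit of > 36600 nM in this assay, at which 4 of the 4 values shown sit.

The compounds shown leave open whether methoxy in place of hydrogen on an aromatic carbon changes the cytotoxicity read-out at all, since none of them yields an actual number.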